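A few compounds are considered here, and "the series" means these few. Any claim that something is new, unique, unknown or untested is made for them only; others in the source may bear on it.

Compound 1 `CC(C)(C)C1=NN(c2ccc(Cl)cc2)C(c2ccc(Cl)cc2)C1`: 11.8%
Compound 2 `CC(C)(C)C1=NN(c2ccc(Cl)cc2)C(c2ccc(Br)cc2)C1`: 39%
Compound 3 `CC(C)(C)C1=NN(c2ccc(Cl)cc2)C(c2ccc(C#N)cc2)C1`: 20.7%

All three were tested in an assay on isolated protein for inhibition of protein kinase C zeta type (Homo sapiens), with a stated time of 4 min, tested at 62.5 uM; on this read-out higher numbers stand for more inhibition at the one concentration tested (going by the name of the read-out) and lower numbers for less inhibition. Compound 3 stands second highest of the three numbers: the step of a number 8.9 percentage points higher from compound 1 to compound 3 (within the scatter) lies within the scatter, while the step of a number 18.3 percentage points lower from compound 2 to compound 3 (beyond the scatter) lies beyond it. Compound 4 `CC(C)(C)C1=NN(c2ccc(Cl)cc2)C(c2cccc(O)c2)C1` has not yet been measured; it differs from compound 3 by 3-hydroxyphenyl in place of 4-cyanophenyl on a saturated ring carbon. Among the compounds with values here, no measured step exchanges a nitrile or a halogen for a hydroxyl group, so none bears directly on this change. The three steps only show how far swaps on this ring have moved the read-out so far, the largest being a number 27.2 percentage points higher from compound 1 to compound 2 (beyond the scatter). A step of modest size at most is therefore expected, in either direction. Compound 4 is estimated at 22%, between 5% and 42%, which would mean a step of a number 1.3 percentage points higher from compound 3 to compound 4 (within the scatter).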

Compound 4, a percentage reported as inhibition, at one concentration (the size of the read-out at that concentration, not a potency): 95.6%
Beside the measured number, compound 4's estimate is 73.6 percentage points below it; measured number outside the range, above it.
By their numbers in this assay, from the lowest: compounds 1 and 3 (each within the scatter of the next); then compound 2; then compound 4.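

In this assay, the change on this saturated ring carbon moves the number much further than the halogen and nitrile swaps did: 3-hydroxyphenyl brings a number 74.9 percentage points higher from compound 3 to compound 4 (beyond the scatter), a number 56.6 percentage points higher from compound 2 to compound 4 (beyond the scatter) and a number 83.8 percentage points higher from compound 1 to compound 4 (beyond the scatter). Within the data shown here, compound 4 therefore stands highest of the four, and each new step exceeds any seen among the earlier compounds. Nothing available explains this jump. The compounds shown do not separate the effect of the hydroxyl group from that of its place on the phenyl ring. As far as these compounds go, whether a methoxy group or an amine in that same place would give a similar number also remains open.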